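The compounds below may be only part of what the source reports. "The series", "measured", "known", "first", "only" and "open" are said of these compounds alone.

Measured compounds:
- compound 1, `C=C1[C@@H](OC(C)=O)C[C@@H]2[C@](C)(CO[Si](C)(C)C(C)(C)C)[C@H](OC(C)=O)CC[C@@]2(C)[C@@H]1C[C@@H](Nc1ccc(Br)cc1)C1=CCOC1=O`, gives 4150 nM in a functional assay on A549 cells (Homo sapiens) for cytotoxicity, read by sulforhodamine B assay; on this read-out higher numbers stand for weaker inhibition and lower numbers for stronger inhibition.
- compound 2, `C=C1[C@@H](OC(C)=O)C[C@@H]2[C@](C)(COC=O)[C@H](OC(C)=O)CC[C@@]2(C)[C@@H]1C[C@@H](Nc1ccc(Br)cc1)C1=CCOC1=O`, gives 15900 nM in this assay.

Compound 1 stands at the lower of the two numbers, which in this assay means the stronger inhibition of the two. Within the data shown here, the only measured step, a 3.8-fold higher number from compound 1 to compound 2 (0.58 log units; beyond the scatter), concerns a group on an oxygen on a saturated carbon and leaves the group on the amine nitrogen untouched. Compound 3, `C=C1[C@@H](OC(C)=O)C[C@@H]2[C@](C)(CO[Si](C)(C)C(C)(C)C)[C@H](OC(C)=O)CC[C@@]2(C)[C@@H]1C[C@@H](Nc1cccc2ccccc12)C1=CCOC1=O`, keeps everything of compound 1 except that group: naphthalen-1-yl in place of 4-bromophenyl on an amine nitrogen. Among the measured compounds shown here, no measured step touches this place, so the data give no direction for the change, and a step that stays within the scatter of compound 1 is the plainest expectation. Compound 3 is therefore estimated at 4000 nM, with a range from 1500 nM to 12000 nM, which amounts to an expected step of a 1.0-fold lower number from compound 1 to compound 3 (0.02 log units; within the scatter).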

Compound 3, half-maximal inhibitory concentration: 4970 nM
Compound 3: middle estimate off by 1.2-fold (0.09 log units), on the low side, and the stated range covers the measured number.
By their numbers in this assay, from the lowest: compounds 1 and 3 (each within the scatter of the next); then compound 2.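

In this assay, naphthalen-1-yl in place of 4-bromophenyl on an amine nitrogen gives a 1.2-fold higher number from compound 1 to compound 3 (0.08 log units; within the scatter), so the two compounds cannot be told apart on this read-out. Among these compounds, this is the first reading at this position, and it shows that a group with two aromatic rings and no bromine can stand there with no change beyond the scatter. Nothing available bears on why this swap makes so little difference.

The compounds shown carry only these two aromatic groups on the nitrogen, so it remains open how a plain phenyl, a pyridine ring, a small chain such as methyl, or a ring carrying a carboxylic acid would read. From the compounds shown here alone, it is also open whether naphthalen-1-yl would read the same alongside the formate ester of compound 2.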